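The source may report more compounds than this note shows. Statements on the series, on what has been measured and on what is new or still open speak of the compounds shown alone.

Working notes on the series, values from a functional assay on KB cells (Homo sapiens) for antiproliferative activity, read by MTT assay, with a stated time of 72 h; on this read-out higher numbers stand for weaker inhibition and lower numbers for stronger inhibition:

- compound 1 `CCOC(=O)c1cc(-c2cc(OC)c(OC)c(OC)c2)c(-c2ccc(OC)c([N+](=O)[O-])c2)s1`: 15800 nM
- compound 2 `CCOC(=O)c1cc(-c2cc(OC)c(OC)c(OC)c2)c(-c2ccc3ccccc3c2)s1`: 5890 nM
- compound 3 `CCOC(=O)c1cc(-c2cc(OC)c(OC)c(OC)c2)c(-c2ccc(OC)c(OCc3ccccc3)c2)s1`: > 100000 nM (a limit, not a number)

Of the two numerical values, compound 1 has the higher one, so it is the less potent of that pair. The nearest value is that of compound 2, with a 2.7-fold lower number from compound 1 to compound 2 (0.43 log units; beyond the scatter). Compound 3 can be placed only through its limit.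

Next in line is compound 4 `COc1ccc(-c2sc(C(=O)O)cc2-c2cc(OC)c(OC)c(OC)c2)cc1[N+](=O)[O-]`, which keeps the core of compound 1 and its aryl groups but carries hydrogen in place of ethyl on an oxygen next to a carbonyl group, turning the ethoxycarbonyl into a carboxy group: hydrogen in place of ethyl on an oxygen next to a carbonyl group.

Among the measured compounds shown here, no measured step touches this place. Both measured steps lie on the aryl group: a 2.7-fold lower number from compound 1 to compound 2 (0.43 log units; beyond the scatter) and an at least 6.3-fold higher number from compound 1 to compound 3 (0.80 log units; beyond the scatter). They therefore bear only indirectly, showing that single changes in this assay can move the number beyond the scatter, in either direction. With so little to go on, a modest rise in the number is expected, and a result within the scatter would not be surprising.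

The expected change is a 1.9-fold higher number from compound 1 to compound 4 (0.28 log units; within the scatter). The estimate for compound 4 is 30000 nM, with an expected range from 8000 nM to 100000 nM.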

Compound 4, half-maximal inhibitory concentration: 35900 nM
Compound 4: middle estimate off by 1.2-fold (0.08 log units), on the low side; low and high end bracket the measured number.
By their numbers in this assay, from the lowest: compound 2; then compound 1; then compound 4. At a limit, above all of these: compound 3.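

The ethoxycarbonyl group now has its first measured step: in this assay, changing it to carboxy gives a 2.3-fold higher number from compound 1 to compound 4 (0.36 log units; beyond the scatter), a shift towards weaker inhibition. The number therefore responds to a change at this oxygen as well as to changes on the aryl group, and the carboxy form still gives a numerical value, with compound 4 at 35900 nM in the same range as compound 1. Nothing measured in the series accounts for this step.

From the compounds shown here alone, it remains open whether the shift follows from losing the ethyl group or from having hydrogen on this oxygen; a methyl ester, a longer chain on the same oxygen or a primary amide in place of the carboxy group would help separate the two readings. The step is also known only with the 4-methoxy-3-nitrophenyl group, so whether the same change has a similar size with naphthalen-2-yl, the aryl group of compound 2, remains undetermined.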